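From 4-nitrophenyl to pyridin-2-yl on a shared core

The source may report more compounds than this note shows. Statements on the series, on what has been measured and on what is new or still open speak of the compounds shown alone.

In a functional assay on HepG2 cells (Homo sapiens) for antiproliferative activity, read by MTT assay, with a stated time of 48 h (a lower number here means a stronger inhibitor, a higher number a weaker inhibitor), compound 1 `CC(=O)N1N=C(c2ccc3ccccc3c2)OC1c1ccccc1Br` gives 3.98 ug/mL while compound 2 `CC(=O)N1N=C(c2ccc3ccccc3c2)OC1c1ccc([N+](=O)[O-])cc1` stands as the higher of the two numbers at 8.1 ug/mL and so is the weaker inhibitor. Compound 3 `CC(=O)N1N=C(c2ccc3ccccc3c2)OC1c1ccccn1` carries pyridin-2-yl in place of 4-nitrophenyl on a saturated ring carbon. Among the measured compounds shown here, the only measured swap at that carbon gave a 2.0-fold higher number from compound 1 to compound 2 (0.31 log units; beyond the scatter) and was modest. One modest step is thin evidence, so a 1.4-fold lower number from compound 2 to compound 3 (0.13 log units; within the scatter) is the expected step in this assay and no shift beyond the scatter is foreseen. For compound 3 the estimate is 6 ug/mL with an expected range from 2.5 ug/mL to 15 ug/mL for this measurement.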

Compound 3, half-maximal inhibitory concentration: 5.26 ug/mL
Compound 3: the middle estimate sits 1.1-fold (0.06 log units) above what was measured; the measured number falls inside the stated range.
By their numbers in this assay, from the lowest: compounds 1, 3 and 2 (each within the scatter of the next, the first and the last beyond it).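

In this assay, the two steps of a 1.5-fold lower number from compound 2 to compound 3 (0.19 log units; within the scatter) and a 1.3-fold higher number from compound 1 to compound 3 (0.12 log units; within the scatter) both stay within the scatter, so a ring with one hetero atom can replace either substituted phenyl ring at this saturated ring carbon with no clear shift. Pyridin-2-yl thus cannot be told apart from either group, even though compound 1 and compound 2 do differ beyond the scatter. No measurement shown here offers an explanation for this. Still open, going by these compounds, is how a group without an aromatic ring, such as an amine or a carboxylic acid, would read at this carbon.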